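The source may hold more compounds than are shown below. What is called first, only, known or untested is meant among the compounds shown, and "the series" means these compounds.

Of the compounds shown here, three have so far been tested in a functional assay (Platelet, plasma) for inhibition, with Homo sapiens as the target; on this read-out higher numbers stand for weaker inhibition and lower numbers for stronger inhibition. Compound 1 `N#Cc1cc2c(nc1N1CCC(C(=O)NS(=O)(=O)Cc3ccccc3)CC1)CCC(Cl)C2=O` gives > 300000 nM, which is a limit of the assay and not a number. Compound 2 `CN1Cc2nc(N3CCC(C(=O)NS(=O)(=O)Cc4ccccc4)CC3)c(C#N)cc2C1=O` gives > 300000 nM, which is also a limit. Going by the values given here, compound 3 `N#Cc1cc2c(nc1N1CCC(C(=O)NS(=O)(=O)Cc3cccc(F)c3)CC1)COC2=O` gives 70500 nM, the only true number available, so it is the one firm reference point. Compound 4 `N#Cc1cc2c(nc1N1CCC(C(=O)NS(=O)(=O)C3(c4ccccc4)CC3)CC1)COC2=O` has 1-phenylcyclopropyl in place of 3-fluorobenzyl on a sulfonyl sulfur. Among the compounds with values here, no measured pair shows a change of this kind, so its size cannot be read from the data. The estimate is a modest 1.4-fold lower number from compound 3 to compound 4 (0.15 log units; within the scatter), expected to lean slightly towards stronger inhibition. Compound 4 is expected at 50000 nM, within an estimated range of 10000 nM to 250000 nM.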

Compound 4, half-maximal inhibitory concentration: 4100 nM
For compound 4 the middle estimate is 12-fold (1.09 log units) above the measured one; measured number below the stated range.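

In this assay, 1-phenylcyclopropyl in place of 3-fluorobenzyl on a sulfonyl sulfur gives a 17-fold lower number from compound 3 to compound 4 (1.24 log units; beyond the scatter), so this position can shift the result well beyond the scatter. The change adds a three-membered ring and removes fluorine at once, and these two parts cannot be separated here. Compound 1 and compound 2 differ in the core and offer no step, as their values are limits of the assay: the limit of > 300000 nM in this assay, at which 2 of the 4 values shown sit.

As far as these compounds go, it remains open whether the three-membered ring alone accounts for the step. Also open, from the compounds shown here alone, is how a larger ring, as in 1-phenylcyclobutyl, would read at this position.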